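This account rests on a few compounds, and the source may have more. Where it says the series, first, only, none or still open, it means among the compounds named here.

Of the compounds shown here, three built on one shared core have been measured in a functional assay on KB cells (Homo sapiens) for cytotoxicity, read by sulforhodamine B assay; a higher number here means a weaker inhibitor, a lower number a stronger inhibitor. Compound 1 `C=C1[C@@H](OC(C)=O)C[C@@H]2[C@](C)(CO[Si](C)(C)C(C)(C)C)[C@H](OC(C)=O)CC[C@@]2(C)[C@@H]1C[C@@H](Nc1cccc(F)c1)C1=CCOC1=O` gives 4560 nM, and compound 2 `C=C1[C@@H](OC(C)=O)C[C@@H]2[C@](C)(CO[Si](C)(C)C(C)(C)C)[C@H](OC(C)=O)CC[C@@]2(C)[C@@H]1C[C@@H](Nc1ccc(C(=O)O)cc1)C1=CCOC1=O` gives 5540 nM; the step of a 1.2-fold higher number from compound 1 to compound 2 (0.08 log units; within the scatter) shows that exchanging one aryl group on the amine nitrogen for the other changes little. Compound 3 `C=C1[C@@H](OC(C)=O)C[C@@H]2[C@](C)(COC=O)[C@H](OC(C)=O)CC[C@@]2(C)[C@@H]1C[C@@H](Nc1cccc2ccccc12)C1=CCOC1=O` gives 32300 nM, the highest of the three numbers and beyond the scatter above both others, so it is the weakest inhibitor of the set. Compound 3 differs from compounds 1 and 2 in two places at once: in the aryl group on the amine nitrogen and in the group on an oxygen on a saturated carbon.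

Compound 4 `C=C1[C@@H](OC(C)=O)C[C@@H]2[C@](C)(CO[Si](C)(C)C(C)(C)C)[C@H](OC(C)=O)CC[C@@]2(C)[C@@H]1C[C@@H](Nc1cccc2ccccc12)C1=CCOC1=O` is not yet measured. It differs from compound 3 in one place: a group of 7 heavy atoms (6 carbon, 1 silicon; no ring) in place of a group of 2 heavy atoms (1 carbon, 1 oxygen; no ring), on an oxygen on a saturated carbon. Within the data shown here, no measured pair isolates this change; the only measured step, from compound 1 to compound 2, concerns the aryl group and lies within the scatter. Still, compound 1 at 4560 nM and compound 2 at 5540 nM both carry the entering group and sit far below compound 3, so part of that gap could belong to the change made here. Compound 4 is therefore expected to give about 11000 nM, within 3500 nM to 35000 nM. This estimate means an expected step of a 2.9-fold lower number from compound 3 to compound 4 (0.47 log units; beyond the scatter) toward a stronger inhibitor, with wide uncertainty.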

Compound 4, half-maximal inhibitory concentration: 8930 nM
For compound 4 the middle estimate is 1.2-fold (0.09 log units) above the measured one, and the stated range covers the measured number.
By their numbers in this assay, from the lowest: compounds 1, 2 and 4 (each within the scatter of the next); then compound 3.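

In this assay, among these compounds, the step of a 3.6-fold lower number from compound 3 to compound 4 (0.56 log units; beyond the scatter) isolates the group on an oxygen on a saturated carbon for the first time: with naphthalen-1-yl held on the amine nitrogen, the group of 7 heavy atoms (6 carbon, 1 silicon) in place of formyl gives a modest change toward a stronger inhibitor, beyond the scatter. With that larger group held on the oxygen, the step of a 1.6-fold higher number from compound 2 to compound 4 (0.21 log units; within the scatter) and the step of a 2.0-fold higher number from compound 1 to compound 4 (0.29 log units; within the scatter) both lie within the scatter, so these measurements do not separate naphthalen-1-yl from 4-carboxyphenyl or 3-fluorophenyl. The high number of compound 3 therefore goes with formyl on that oxygen and not with naphthalen-1-yl on the nitrogen, although this reading rests on a single pair.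

The compounds shown leave open where an acetyl group or a plain hydrogen on that oxygen would fall, and whether the same exchange gives a similar step with 3-fluorophenyl or 4-carboxyphenyl on the amine nitrogen. Nothing available gives a reason for the step seen at this position.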